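The compounds below may be only part of what the source reports. "The series", "measured", "known", "first", "only" and "open" are said of these compounds alone.

Values in an ADME assay on cells (Hepatocyte, Mus musculus) for metabolic stability (on this read-out lower numbers stand for a shorter-lived compound and higher numbers for a longer-lived compound), for the compounds measured so far:

- Compound 1 `O=C(OC1CCC(CN2CCN(c3cc(=O)c4cc(C(F)(F)F)cc([N+](=O)[O-])c4s3)CC2)CC1)c1ccccc1` gives 0.903 h
- Compound 2 `CS(=O)(=O)NC1CCC(CN2CCN(c3cc(=O)c4cc(C(F)(F)F)cc([N+](=O)[O-])c4s3)CC2)CC1` gives > 1.55 h as a limit
- Compound 3 `O=c1cc(N2CCN(CC3CCC(NS(=O)(=O)c4ccccc4)CC3)CC2)sc2c([N+](=O)[O-])cc(C(F)(F)F)cc12` gives > 1.55 h as a limit

Compound 3 reports > 1.55 h in this assay and this is a limit, not a number. For the measured compounds named here, the set therefore holds the limit of > 1.55 h in this assay, at which 2 of the 3 values shown sit, and only one true number.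

The next compound, compound 4 `O=C(NC1CCC(CN2CCN(c3cc(=O)c4cc(C(F)(F)F)cc([N+](=O)[O-])c4s3)CC2)CC1)c1ccccc1`, has benzoyl in place of phenylsulfonyl on an amine nitrogen and so turns (phenylsulfonyl)amino into benzamido.

Going by the values given here, two measured steps bear on this change, an at least 1.7-fold higher number from compound 1 to compound 2 (0.23 log units; that floor lies within the scatter) and an at least 1.7-fold higher number from compound 1 to compound 3 (0.23 log units; that floor lies within the scatter), and both start from benzoyloxy. That group also contains benzoyl, so compound 1 is the nearest relative on that side. A third step, a step that the two limits leave unreadable from compound 2 to compound 3, gives no size to work with. Among the compounds with values here, no measured compound carries benzamido.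

No step beyond the usual scatter is expected, with only a slight lean towards a shorter life, given compound 1 at 0.903 h in this assay. The expected change is an at least 1.0-fold lower number from compound 3 to compound 4 (0.01 log units; that floor lies within the scatter) in this estimate. For compound 4 the estimated half-life is 1.5 h with an expected range from 0.8 h to 2.8 h in this assay.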

Compound 4, half-life: > 1.55 h
Compound 4 was reported as a limit (the forecaster's own chance of this, stated with the estimate: 50%); middle value at least 1.0-fold (0.01 log units) from the limit.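

In this assay compound 4 gives > 1.55 h, and this is a limit, not a number. This result adds benzamido to methanesulfonamido and (phenylsulfonyl)amino as a third group, joined through an amine nitrogen to the saturated ring carbon, that sits at the same limit, leaving compound 1, with benzoyloxy, as the only true number in the set: the limit of > 1.55 h in this assay, at which 3 of the 4 values shown sit.

Compound 1 and compound 4 share the benzoyl group and differ only in the link to the ring, an oxygen in benzoyloxy and an amine nitrogen in benzamido, and this exchange gives an at least 1.7-fold higher number from compound 1 to compound 4 (0.23 log units; that floor lies within the scatter).

The steps among compound 2, compound 3 and compound 4 cannot be read, so the benzoyl, methylsulfonyl and phenylsulfonyl groups on this nitrogen cannot be ranked, and how far any of these compounds truly lies from compound 1 remains open. On these data alone, it is also open where a plain amine or a carboxylic acid on the saturated ring carbon would fall on this read-out.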